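Des-chloro analogue of compound 1: expected antiproliferative potency

The source may report more compounds than this note shows. Statements on the series, on what has been measured and on what is new or still open speak of the compounds shown alone.

Measured compounds:
- compound 1 `O=C1C=CC2(C=C1)OCC(=O)N2c1nc(-c2ccc3ccccc3c2)nn1-c1ccc(Cl)cc1`: 400 nM
- compound 2 `CC1OC2(C=CC(=O)C=C2)N(c2nc(-c3cccc4ccccc34)nn2-c2ccccc2)C1=O`: 180 nM
- compound 3 `Cc1ccc(-n2nc(-c3ccc4ccccc4c3)nc2N2C(=O)C(C)OC23C=CC(=O)C=C3)cc1`: 1210 nM

In a functional assay on A549 cells (Homo sapiens) for antiproliferative activity, with a stated time of 5 days (on this read-out higher numbers stand for weaker inhibition and lower numbers for stronger inhibition), compound 1 gives 400 nM and stands second highest of the three numbers. Compound 2 gives 180 nM, a number lower than that of compound 1 by more than the scatter, while compound 3 gives 1210 nM, a number higher than that of compound 1 by more than the scatter. Compounds 2 and 3 each differ from compound 1 in more than one place, so no single change can be read from their values.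

Compound 4 `O=C1C=CC2(C=C1)OCC(=O)N2c1nc(-c2ccc3ccccc3c2)nn1-c1ccccc1` is not yet measured. It differs from compound 1 in one place: hydrogen in place of chloro on an aromatic carbon. Among the measured compounds shown here, no measured pair shows this change on its own, so the expectation for the step rests on the values at hand alone. The step of a 1.3-fold lower number from compound 1 to compound 4 (0.12 log units; within the scatter) in this assay is estimated to be small, if anything toward a lower number, and may well fall within the scatter. Compound 4 is expected to give about 300 nM, with a likely range from 120 nM to 800 nM.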

Compound 4, half-maximal inhibitory concentration: 140 nM
Compound 4: the middle estimate sits 2.1-fold (0.33 log units) above what was measured; the range from low to high includes it.
By their numbers in this assay, from the lowest: compounds 4 and 2 (each within the scatter of the next); then compound 1; then compound 3.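

Hydrogen in place of chloro on an aromatic carbon, para to a large group, gives a 2.9-fold lower number from compound 1 to compound 4 (0.46 log units; beyond the scatter) in this assay, the first single change that can be read in this series. The earlier compounds shown here each differed in more than one place and could not isolate this position; this pair shows that the position responds to substitution and that 4-chlorophenyl to phenyl is not neutral here. The chloro is also not required for activity at this level, as the unsubstituted phenyl of compound 4 gives 140 nM. Nothing at hand accounts for the size or direction of this step.

Open, on these data alone, is how a fluoro, a methoxy or an amine at this same position would read in this assay. Also open, as far as these compounds go, is whether the same change carries over to the other parts of the scaffold seen in compound 2 and compound 3.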